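From Nitro to Bromo: A Small Step Expected

This account rests on a few compounds, and the source may have more. Where it says the series, first, only, none or still open, it means among the compounds named here.

In a functional assay on MCF7 cells (Homo sapiens) for cytotoxicity, read by MTT assay, with a stated time of 24 h (on this read-out lower numbers stand for stronger inhibition and higher numbers for weaker inhibition), compound 1 `O=C(NC(=S)Nc1nc2ccccc2s1)c1ccccc1` gives 37300 nM. Compound 3 `O=C(NC(=S)Nc1nc2cc([N+](=O)[O-])ccc2s1)c1ccccc1` adds a nitro to that core and gives 41600 nM. Compound 2 `CCCCC(=O)NC(=S)Nc1nc2cc(Br)ccc2s1` carries a bromo and a pentanoyl chain and gives 45700 nM. Compound 3 lies within the scatter of both others, so these numbers set it in no clear order.

The next structure, compound 4 `O=C(NC(=S)Nc1nc2cc(Br)ccc2s1)c1ccccc1`, differs from compound 3 in one group: bromo in place of nitro on an aromatic carbon. Put simply, it has bromo in place of nitro on an aromatic carbon.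

Within the data shown here, one measured step bears directly on this carbon: a 1.1-fold higher number from compound 1 to compound 3 (0.05 log units; within the scatter). Replacing hydrogen with nitro there therefore produced no change that can be told from the scatter. Among the measured compounds shown here, compound 2 is the only measured compound with a bromo, and its 45700 nM is also close to the value of compound 3, although its chain differs. For the measured compounds named here, no measured pair isolates bromo on the core of compound 4, so this support is indirect.

The expected change is a 1.0-fold lower number from compound 3 to compound 4 (0.02 log units; within the scatter), which would stay within the scatter, with no firm direction. Compound 4 is estimated at 40000 nM, with an expected range from 24000 nM to 65000 nM.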

Compound 4, half-maximal inhibitory concentration: 32100 nM
Beside the measured number, compound 4's estimate is 1.2-fold (0.10 log units) above it, and the stated range covers the measured number.
By their numbers in this assay, from the lowest: compounds 4, 1, 3 and 2 (each within the scatter of the next).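

In this assay the direct swap of nitro for bromo on this aromatic carbon gives a 1.3-fold lower number from compound 3 to compound 4 (0.11 log units; within the scatter) and so shows, on one shared core, that these two groups cannot be told apart here. Among these compounds, the first direct reading of bromo against hydrogen on the same carbon is a 1.2-fold lower number from compound 1 to compound 4 (0.07 log units; within the scatter) and it agrees with the earlier nitro result: hydrogen, nitro and bromo at this place all give numbers within the scatter of one another. A second place also gets its first one-change comparison, as keeping the bromo and putting phenyl in place of butyl on the carbonyl carbon gives a 1.4-fold lower number from compound 2 to compound 4 (0.15 log units; within the scatter) and this too stays within the scatter.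

Going by these compounds, whether an amine or a carboxylic acid on this aromatic carbon, or a longer chain on the carbonyl carbon, would move the number beyond the scatter remains open. Nothing available here offers an explanation for why these four compounds sit so close together.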